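Chloro for hydrogen on the phenyl of compound 3

The compounds below may be only part of what the source reports. "The series", "measured", "known", "first", "only" and "open" are said of these compounds alone.

Measured compounds:
compound 1, `Fc1ccc(Nc2cc(Nc3ccc(Oc4ccncc4-c4cccnc4)c(F)c3)ncn2)cc1`, 710 nM
compound 2, `O=C(Nc1ccc(Oc2ccncc2-c2cccnc2)c(F)c1)c1nn(-c2cccc(F)c2)c(=O)c2ccccc12`, 1750 nM
compound 3, `O=C(Nc1ccc(Oc2ccncc2-c2cccnc2)c(F)c1)c1nn(-c2ccccc2)c(=O)c2ccccc12`, 7900 nM

All three were tested in a functional assay on A549 cells (Homo sapiens) for cytotoxicity, read by MTT assay, with a stated time of 72 h; on this read-out higher numbers stand for weaker inhibition and lower numbers for stronger inhibition. Compound 3 gives the highest number of the three; its nearest neighbour is compound 2, and compound 1 stands furthest away. Among the measured compounds shown here, the only single-point step among the measured compounds is a 4.5-fold higher number from compound 2 to compound 3 (0.65 log units; beyond the scatter), which means that removing the fluoro from the phenyl of compound 2 made the number higher by a modest amount.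

Compound 4, `O=C(Nc1ccc(Oc2ccncc2-c2cccnc2)c(F)c1)c1nn(-c2ccc(Cl)cc2)c(=O)c2ccccc12`, is compound 3 with chloro in place of hydrogen on an aromatic carbon. For the measured compounds named here, the new group sits where no measured compound carries one, so the step from compound 2 to compound 3 bears on it only loosely: that step shows a substituent on this phenyl can lower the number, but at a different place and with a different group. The expectation is therefore a modest lowering of the number rather than none, with a range wide enough to include no change.

Compound 4 is estimated at 3000 nM, expected between 1000 nM and 9000 nM, corresponding to an expected step of a 2.6-fold lower number from compound 3 to compound 4 (0.42 log units; beyond the scatter).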

Compound 4, half-maximal inhibitory concentration: 1020 nM
Compound 4: middle estimate off by 2.9-fold (0.47 log units), on the high side, and the stated range covers the measured number.
By their numbers in this assay, from the lowest: compounds 1, 4 and 2 (each within the scatter of the next, the first and the last beyond it); then compound 3.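

In this assay, among the compounds shown here, the phenyl of compound 3 proves sensitive to a single added atom: chloro in place of hydrogen, para to a large group, gives a 7.7-fold lower number from compound 3 to compound 4 (0.89 log units; beyond the scatter) and is the first measured change at this place on the ring. Compound 4 also bears on the earlier fluoro result, since 4-chlorophenyl in place of 3-fluorophenyl gives a 1.7-fold lower number from compound 2 to compound 4 (0.23 log units; within the scatter), which lies within the scatter, so both substituted phenyl compounds sit on the same side of compound 3 and cannot be ranked against each other. Among these three compounds, the unsubstituted phenyl gives the highest number, and neither substituted compound goes against that, although no measurement shown explains why the added halogen lowers the number.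

Because compound 2 and compound 4 differ in both the group and its place on the ring, the contribution of each remains unseparated. As far as these compounds go, it also remains open whether the lower number is specific to a halogen or would also appear with a methoxy group, an amine or a carboxylic acid at this same place.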